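Three Measured Compounds and an Untested Pyridine Cousin

This account rests on a few compounds, and the source may have more. Where it says the series, first, only, none or still open, it means among the compounds named here.

Compound 1, `O=C(O)Cc1sc(CSc2ccccc2)nc1-c1ccc(Cl)cc1`, gives 450 nM in an in vitro functional assay on HEK285-7 cells for antagonist activity at prostaglandin D2 receptor 2 (Homo sapiens), read by BRET and beta-arrestin recruitment; a lower number here means a stronger inhibitor, a higher number a weaker inhibitor.
Compound 2, `O=C(O)Cc1sc(CS(=O)(=O)c2ccc(Cl)cc2)nc1-c1ccc(Cl)cc1`, gives 730 nM in this assay.
Compound 3, `CS(=O)(=O)Nc1cccc(-c2nc(C(c3ccc(F)cc3)c3ccc(F)cc3)sc2CC(=O)O)c1`, gives 370 nM in this assay.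

Compound 3 has the lowest of the three numbers, but both compound 1 and compound 2 sit within the usual scatter of it, so no ranking among the three is justified. The unmeasured compound 4, `CN(C)c1cc(-c2nc(C(c3ccc(F)cc3)c3ccc(F)cc3)sc2CC(=O)O)ccn1`, differs from compound 3 in one place: 2-(dimethylamino)pyridin-4-yl in place of 3-(methanesulfonamido)phenyl on an aromatic carbon. Among the compounds with values here, no measured pair shows this kind of swap, so its effect can only be guessed. A modest step is expected, leaning toward a weaker inhibitor, as expressed by a 1.6-fold higher number from compound 3 to compound 4 (0.21 log units; within the scatter). Compound 4 is therefore estimated at 600 nM in this assay, within a range from 200 nM to 1800 nM.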

Compound 4, half-maximal inhibitory concentration: > 100000 nM
Compound 4: no number, only a limit; the forecaster's own chance of this, stated with the estimate: 5%; at least 160-fold (2.22 log units) between middle value and limit.
By their numbers in this assay, from the lowest: compounds 3, 1 and 2 (each within the scatter of the next). At a limit, above all of these: compound 4.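

Compound 4 gives no number in this assay, only a limit: the limit of > 100000 nM in this assay, at which 1 of the 4 values shown sits. The earlier compounds shown here held no one-place step, and this first one shows that the aromatic carbon next to the ring nitrogen is sensitive to the group it carries: putting 2-(dimethylamino)pyridin-4-yl in place of 3-(methanesulfonamido)phenyl gives an at least 270-fold higher number from compound 3 to compound 4 (2.43 log units; beyond the scatter).

The compounds shown do not separate the loss of the methanesulfonamido group from the arrival of the pyridine nitrogen or the dimethylamino group. A phenyl ring carrying only a dimethylamino group at this carbon would help to tell these apart.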